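Series notes: ethynyl in place of 3-fluorophenyl

A few compounds are considered here, and "the series" means these few. Any claim that something is new, unique, unknown or untested is made for them only; others in the source may bear on it.

Measured so far:
compound 1 `COc1ccccc1NC(=O)c1ccnc2cc(Br)ccc12`: only a limit in a functional assay on KYSE-70 cells for antiproliferative activity against KYSE-70 cell line (Homo sapiens), read by MTT assay, with a stated time of 72 h (on this read-out lower numbers stand for stronger inhibition and higher numbers for weaker inhibition), > 20000 nM
compound 2 `COc1ccc(NC(=O)c2cc(=O)[nH]c3cc(Br)ccc23)cc1`: only a limit, > 20000 nM
compound 3 `O=C(Nc1cccc(F)c1)c1cc(=O)[nH]c2cc(-c3cccc(F)c3)ccc12`: 12000 nM

Compound 3 stands as the only numeric result in this assay; compound 1 and compound 2 both sit at the limit of > 20000 nM in this assay, at which 2 of the 3 values shown sit. Compound 4 `C#Cc1ccc2c(C(=O)Nc3cccc(F)c3)cc(=O)[nH]c2c1` differs from compound 3 by ethynyl in place of 3-fluorophenyl on an aromatic carbon. Within the data shown here, no measured step covers this change, so nothing in the data sets its size. The step is expected to be small, likely none beyond the scatter, with a slight lean toward weaker inhibition, giving a 1.3-fold higher number from compound 3 to compound 4 (0.10 log units; within the scatter). For compound 4 the expected value in this assay is 15000 nM, within 5000 nM to 50000 nM, and a limit rather than a number remains a real possibility.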

Compound 4, half-maximal inhibitory concentration: 9500 nM
Compound 4: middle estimate off by 1.6-fold (0.20 log units), on the high side, and the stated range covers the measured number.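

In this assay, ethynyl in place of 3-fluorophenyl on this aromatic carbon gives a 1.3-fold lower number from compound 3 to compound 4 (0.10 log units; within the scatter). Among these compounds, this is the first readable step, and it shows that the position carries either the aromatic ring of 3-fluorophenyl or the ringless ethynyl with no difference beyond the scatter.

On these data alone, whether an amine, a carboxylic acid or a longer chain at this position would shift the number beyond the scatter stays open. No other step can be read, and the remaining values are limits, not numbers: the limit of > 20000 nM in this assay, at which 2 of the 4 values shown sit.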